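Changing the side chain on the ring nitrogen of compound 3

This account rests on a few compounds, and the source may have more. Where it says the series, first, only, none or still open, it means among the compounds named here.

Going by the values given here, in a functional assay on SU-DHL-6 cells (Homo sapiens) for antiproliferative activity, read by CCK-8 assay, with a stated time of 72 h (a lower number here means a stronger inhibitor, a higher number a weaker inhibitor), compound 3 `COc1ncc(-c2ccc3ncnc(NCCN4CCCCC4)c3c2)cc1NS(C)(=O)=O` gives 320 nM, the lowest of the three numbers so far. Compound 2 `COc1ncc(-c2ccc3ncnc(NCCN4CCCCC4)c3c2)cc1NS(=O)(=O)C1CC1` gives 410 nM, which is within the scatter of that value, while compound 1 `COc1ncc(-c2ccc3ncnc(N(C)CCN(C)C)c3c2)cc1NS(C)(=O)=O` gives 1700 nM.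

Compound 4 `COc1ncc(-c2ccc3ncnc(N[C@H]4CCN(C(=O)C(C)(C)C)C4)c3c2)cc1NS(C)(=O)=O` carries 1-((tert-butyl)carbonyl)pyrrolidin-3-yl in place of 2-(piperidin-1-yl)ethyl on a nitrogen on an aromatic ring.

Among the compounds with values here, the one measured change at this place is a 5.3-fold lower number from compound 1 to compound 3 (0.73 log units; beyond the scatter), beyond the scatter, so this place can move the number. The sulfonyl change, a 1.3-fold lower number from compound 2 to compound 3 (0.11 log units; within the scatter), lies elsewhere and bears little on it. Within the data shown here, no measured compound carries the entering group, so the data give no direction. A step of similar size is possible either way, and the central expectation in this assay is none beyond the scatter.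

The expected step is a 1.3-fold higher number from compound 3 to compound 4 (0.10 log units; within the scatter).

Compound 4 is estimated at 400 nM, with an expected range of 100 nM to 1500 nM.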

Compound 4, half-maximal inhibitory concentration: 7600 nM
Compound 4: middle estimate off by 19-fold (1.28 log units), on the low side, and the stated range ends below it.
By their numbers in this assay, from the lowest: compounds 3 and 2 (each within the scatter of the next); then compound 1; then compound 4.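

In this assay the side chain on a nitrogen on an aromatic ring proves far more sensitive than the earlier step at this place, a 5.3-fold lower number from compound 1 to compound 3 (0.73 log units; beyond the scatter), suggested: the new step is a 24-fold higher number from compound 3 to compound 4 (1.38 log units; beyond the scatter), and it is large. The change swaps 2-(piperidin-1-yl)ethyl for 1-((tert-butyl)carbonyl)pyrrolidin-3-yl, which alters the ring size, adds a carbonyl and a defined stereocentre, and lengthens the group, so this one step cannot be assigned to any single one of these features. Nothing measured here accounts for the size of the step.

Open, going by these compounds, is whether the pyrrolidin-3-yl ring with a free ring amine or an N-methyl group in place of the tert-butyl carbonyl would stay near compound 3. Also open, on these data alone, is how the opposite stereocentre or a 3-(piperidin-1-yl)propyl chain would read.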